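A difluorophenyl swap in a series at its limit

The compounds below may be only part of what the source reports. "The series", "measured", "known", "first", "only" and "open" are said of these compounds alone.

In a functional assay on MCF7 cells (Homo sapiens) for cytotoxicity, read by MTT assay, with a stated time of 48 h (on this read-out higher numbers stand for weaker inhibition and lower numbers for stronger inhibition), compound 3 (`COc1ccc(-c2cn(C(C)=O)c(=O)n2-c2cc(OC)c(OC)c(OC)c2)cc1`) gives > 50000 nM as a limit and not a number. Compound 2 (`COc1cc(-n2c(-c3ccc([N+](=O)[O-])cc3)cn(C(C)=O)c2=O)cc(OC)c1OC`) gives > 50000 nM as a limit too. Compound 1 (`COc1cc(-n2c(-c3ccc(Cl)cc3)cn(C(C)=O)c2=O)cc(OC)c1OC`) has "not determined" (no result reported) here. Compound 4 (`COc1cc(-n2c(-c3ccc(F)cc3F)cn(C(C)=O)c2=O)cc(OC)c1OC`) puts 2,4-difluorophenyl in place of 4-methoxyphenyl on an aromatic carbon of the shared core. Among the compounds with values here, the only measured step is a step that the two limits leave unreadable from compound 2 to compound 3 and it offers no size to carry over. The data so far give the limit of > 50000 nM in this assay, at which 2 of the 3 values shown sit, and no actual number. So no step beyond the scatter is expected in this assay and another limit is likely. Compound 4 is estimated at 50000 nM with an expected range from 15000 nM to 150000 nM for repeated measurements. That estimate means a number no higher from compound 3 to compound 4 (the limit leaves the size open) as the expected step.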

Compound 4, half-maximal inhibitory concentration: 49300 nM
For compound 4 the middle estimate is 1.0-fold (0.01 log units) above the measured one; low and high end bracket the measured number.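

With 2,4-difluorophenyl at this aromatic carbon, the series gives its first actual number: in this assay compound 4 gives 49300 nM. Measured against the 4-methoxyphenyl and 4-nitrophenyl groups, the swap reads as an at least 1.0-fold lower number from compound 3 to compound 4 (0.00 log units; that floor lies within the scatter) and an at least 1.0-fold lower number from compound 2 to compound 4 (0.00 log units; that floor lies within the scatter). These steps are only floors, since the true sizes stay hidden behind compounds 2 and 3, whose values are limits: the limit of > 50000 nM in this assay, at which 2 of the 4 values shown sit.

Going by these compounds, whether an amine on this phenyl ring, or a longer chain in place of the acetyl group, would give a number far from that limit remains open.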